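The compounds below may be only part of what the source reports. "The series", "measured", "known", "first", "only" and "open" are said of these compounds alone.

Values measured in a functional assay on A-375 cells (Homo sapiens) for antiproliferative activity (on this read-out higher numbers stand for weaker inhibition and lower numbers for stronger inhibition), are these:
- compound 1 `CCCCO/N=C/c1c(N)ncnc1Oc1ccc2[nH]c(C)cc2c1F` gives 446 nM on this read-out
- compound 2 `Cc1cc2c(F)c(Oc3ncnc(N)c3/C=N/OCc3ccccc3)ccc2[nH]1` gives 62 nM on this read-out
- compound 3 `CCCO/N=C/c1c(N)ncnc1Oc1ccc2[nH]c(C)cc2c1F` gives 28 nM on this read-out

Compound 3 holds the lowest number of the three, with compound 2 nearest and compound 1 furthest. The next step leads to compound 4 `COCCO/N=C/c1c(N)ncnc1Oc1ccc2[nH]c(C)cc2c1F` with the change methoxy in place of methyl on a saturated chain carbon, two bonds along the chain from an oxygen on an unsaturated carbon in the same chain. Here methoxy stands in place of methyl on a saturated chain carbon, two bonds along the chain from an oxygen on an unsaturated carbon, so propoxy becomes 2-methoxyethoxy.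

The closest evidence is a 16-fold lower number from compound 1 to compound 3 (1.20 log units; beyond the scatter) and it is large, with hydrogen in place of methyl further out on this chain. Extending the chain need not cost that much, though: the modest 2.2-fold lower number from compound 2 to compound 3 (0.35 log units; beyond the scatter) leaves the phenyl of compound 2 not far behind. Among the compounds with values here, no measured step places an oxygen in the chain, so that part of the change remains untested.

In this assay the expected change is a 3.2-fold higher number from compound 3 to compound 4 (0.51 log units; beyond the scatter) and so a modest rise in the number, smaller than the large step. The estimated value for compound 4 is 90 nM with an expected range from 25 nM to 320 nM on this read-out.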

Compound 4, half-maximal inhibitory concentration: 233 nM
Beside the measured number, compound 4's estimate is 2.6-fold (0.41 log units) below it; the range from low to high includes it.
By their numbers in this assay, from the lowest: compound 3; then compound 2; then compounds 4 and 1 (each within the scatter of the next).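

In this assay, within the data shown here, the first step that puts an oxygen into the chain gives a clear loss against propoxy (an 8.3-fold higher number from compound 3 to compound 4 (0.92 log units; beyond the scatter)), so 2-methoxyethoxy is not an even exchange for propoxy at this position. Among these compounds, the new compound also falls behind the phenyl-ended chain (a 3.8-fold higher number from compound 2 to compound 4 (0.57 log units; beyond the scatter)) and stands within the scatter of the all-carbon chain of compound 1 (a 1.9-fold lower number from compound 1 to compound 4 (0.28 log units; within the scatter)), so among the four compounds, the oxygen-containing chain gives no gain over that all-carbon chain, and compound 3 remains the only one with a number this low. Nothing measured here explains the rise.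

Compounds 1 and 4 leave open whether the outcome follows the oxygen itself or mainly the extension beyond propoxy, and the steep change around propoxy is seen from the longer side only. An ethoxy or methoxy chain would test the shorter side, while a 2-aminoethoxy chain, with an amine in place of the methoxy, would show whether the loss at this position holds for another heteroatom-bearing chain end.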